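Formyl on the Five-Membered Ring of Compound 1

The source may hold more compounds than are shown below. What is called first, only, known or untested is meant among the compounds shown, and "the series" means these compounds.

Compound 1 `COC(=O)[C@@]1(C)CCC=C2[C@@H]1CC[C@@H](C)[C@]2(C)Cc1c[nH]c2ccccc12` is the reference point. In a functional assay on A549 cells (Homo sapiens) for inhibition, read by sulforhodamine B assay, with a stated time of 48 h (a lower number here means a stronger inhibitor of growth, a higher number a weaker inhibitor of growth), compound 1 gives 5000 nM, the lowest of the three numbers recorded. Compound 2 `COC(=O)[C@@]1(C)CCC=C2[C@@H]1CC[C@@H](C)[C@]2(C)Cc1c[nH]c2ccc(C)cc12` carries methyl in place of hydrogen on an aromatic carbon; in this assay compound 2 gives 17000 nM, a step of a 3.4-fold higher number from compound 1 to compound 2 (0.53 log units; beyond the scatter). Compound 3 `COC(=O)[C@@]1(C)CCC=C2[C@@H]1CC[C@@H](C)[C@]2(C)Cc1c[nH]c2ccc(F)cc12` carries fluoro in place of hydrogen on an aromatic carbon; in this assay compound 3 gives 6200 nM, a step of a 1.2-fold higher number from compound 1 to compound 3 (0.09 log units; within the scatter). Between the two substituted compounds the step is a 2.7-fold lower number from compound 2 to compound 3 (0.44 log units; beyond the scatter).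

Compound 4 `COC(=O)[C@@]1(C)CCC=C2[C@@H]1CC[C@@H](C)[C@]2(C)Cc1c(C=O)[nH]c2ccccc12` differs from compound 1 by formyl in place of hydrogen on an aromatic carbon. The measured steps from compound 1 concern a different aromatic carbon of the shared core and neither a formyl group nor the five-membered aromatic ring, so they bear on the new change only loosely. They show that a small group on the aromatic part of the core shifted the number in this assay by nothing to a modest amount, always toward weaker inhibition. Among the measured compounds shown here, with no closer precedent, the expected step is a 1.1-fold higher number from compound 1 to compound 4 (0.04 log units; within the scatter), which is within the scatter. Compound 4 is therefore estimated at 5500 nM, with a range from 1500 nM to 18000 nM.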

Compound 4, concentration for 50% growth inhibition: 45000 nM
The estimate for compound 4 lay 8.2-fold (0.91 log units) below the measured number, outside the stated range (above it).
By their numbers in this assay, from the lowest: compounds 1 and 3 (each within the scatter of the next); then compound 2; then compound 4.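

In this assay, formyl in place of hydrogen on an aromatic carbon of the five-membered aromatic ring gives a 9.0-fold higher number from compound 1 to compound 4 (0.95 log units; beyond the scatter), a larger step than either of those from compound 1 to compound 2 or to compound 3. This position, next to the ring nitrogen and next to the ring atom that bears a large group, therefore does not tolerate every change as quietly as the fluoro substitution on the other aromatic carbon did, and this change moves the number further toward weaker inhibition of growth than the methyl substitution did. No measurement shown here accounts for the size of this step.

Both the group and its place differ from the earlier changes, so compound 4 alone cannot separate the effect of formyl from the effect of substituting this carbon at all. On these data alone, whether a methyl, a hydroxymethyl or a carboxylic acid on this same carbon would give a number close to that of compound 1 or close to that of compound 4 remains open, as does how formyl would behave on the other aromatic carbon.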